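The source may hold more compounds than are shown below. What is called first, only, known or untested is meant among the compounds shown, and "the series" means these compounds.

Measured so far in an assay on isolated protein for binding affinity to Gonadotropin-releasing hormone receptor (Rattus norvegicus); a higher number here means a weaker inhibitor, a lower number a stronger inhibitor:
compound 1 `Cc1ccc(CNC(=O)c2ccc(Cc3cc4c(cc3C)C(C)(C)CCC4(C)C)o2)cc1` gives 60 nM
compound 2 `Cc1cc2c(cc1Cc1ccc(C(=O)NCc3ccc(CN)cc3)o1)C(C)(C)CCC2(C)C` gives 280 nM
compound 3 `Cc1cc2c(cc1Cc1ccc(C(=O)NCC3CCCC(CN)C3)o1)C(C)(C)CCC2(C)C` gives 890 nM

Among these three, compound 3 stands at the highest number. The step of a 3.2-fold higher number from compound 2 to compound 3 (0.50 log units; beyond the scatter) sets it apart from its nearest neighbour, and the step of a 15-fold higher number from compound 1 to compound 3 (1.17 log units; beyond the scatter) from the furthest. Both lie beyond the scatter, so compound 3 is the weakest binder of the three in this assay.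

Compound 4 `Cc1cc2c(cc1Cc1ccc(C(=O)NCC3CCN(C(=N)N)CC3)o1)C(C)(C)CCC2(C)C` differs from compound 3 in one place: a group of 9 heavy atoms (6 carbon, 3 nitrogen; one six-membered non-aromatic ring with 1 hetero atom) in place of a group of 8 heavy atoms (7 carbon, 1 nitrogen; one six-membered non-aromatic ring of carbon only), on a saturated chain carbon bound to an amide-type nitrogen. Among the compounds with values here, two measured steps bear on this. The step of a 3.2-fold higher number from compound 2 to compound 3 (0.50 log units; beyond the scatter) changed the group at the same place, and the step of a 4.7-fold higher number from compound 1 to compound 2 (0.67 log units; beyond the scatter) added an amino group to the chain that ends the amide. Within the data shown here, both moved the number upward, but neither introduces a group like the one entering here, which has no counterpart among the measured compounds. The change keeps a six-membered non-aromatic ring and keeps hydrogen-bond donors at the end of the chain, so the step of a 1.5-fold lower number from compound 3 to compound 4 (0.17 log units; within the scatter) is expected to be small, toward a lower number if anything. Compound 4 is therefore estimated at 600 nM, within a range from 150 nM to 3000 nM.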

Compound 4, inhibition constant: 2040 nM
Estimate against measurement, compound 4: 3.4-fold (0.53 log units) below, and the stated range covers the measured number.
By their numbers in this assay, from the lowest: compound 1; then compound 2; then compound 3; then compound 4.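

In this assay, the group entering on a saturated chain carbon bound to an amide-type nitrogen moved the number upward once more, with a 2.3-fold higher number from compound 3 to compound 4 (0.36 log units; beyond the scatter), so a six-membered non-aromatic ring with 1 hetero atom and 2 hydrogen-bond donors did not restore binding at this place. Set against the 4-(aminomethyl)phenyl group the same change gives a 7.3-fold higher number from compound 2 to compound 4 (0.86 log units; beyond the scatter), and set against the 4-methylphenyl group it gives a 34-fold higher number from compound 1 to compound 4 (1.53 log units; beyond the scatter), which makes compound 4 the weakest binder of the four and leaves every nitrogen-bearing group shown at a higher number than 4-methylphenyl, with no compound here going against that. Nothing shown here gives a reason for this rise.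

On these data alone, it remains open whether the rise follows the ring, the group carried on its nitrogen, or both, and an unsubstituted piperidine at this place would separate those readings. Also open, as far as these compounds go, is how a carboxylic acid or a longer chain ending in an amine would stand at this same place.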